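The source may hold more compounds than are shown below. What is called first, only, known or untested is meant among the compounds shown, and "the series" means these compounds.

Measured so far in this series:

compound 1, `O=C(c1ccccc1)c1ccc(NC(=O)c2cc(Cl)ccc2O)cc1`: 48000 nM
compound 2, `O=C(c1ccccc1)c1ccc(NC(=O)c2cc(Br)ccc2O)cc1`: 21800 nM
compound 3, `O=C(Oc1ccc(Cl)cc1C(=O)Nc1ccc(C(F)(F)F)cc1)c1cnc(Cl)cn1`: 1100 nM

All three numbers come from an ADME assay on MONO-MAC-6 cells (Homo sapiens) for cytotoxicity, read by MTT assay, with a stated time of 16 h; on this read-out higher numbers stand for weaker inhibition and lower numbers for stronger inhibition. Compound 1 and compound 2 share one core and differ in one place only, (bromo in place of chloro on an aromatic carbon); the step between them is a 2.2-fold lower number from compound 1 to compound 2 (0.34 log units; beyond the scatter). Compound 3 gives the lowest number of the three, and the difference between its core and the core of compound 1 is not broken down here; the two simply stand as they do in this assay.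

Compound 4, `O=C(Oc1ccc(Br)cc1C(=O)Nc1ccc(C(F)(F)F)cc1)c1cnc(Cl)cn1`, has not yet been measured. It differs from compound 3 by bromo in place of chloro on an aromatic carbon. This is the same kind of change as from compound 1 to compound 2, not the same: around the place, the ring carbon in compound 1 is para to a hydroxy group, whereas in compound 3 it is para to a ((5-chloropyrazin-2-yl)carbonyl)oxy group.

The step from compound 3 to compound 4 in this assay is expected to be a 1.7-fold lower number from compound 3 to compound 4 (0.23 log units; within the scatter), set beside a 2.2-fold lower number from compound 1 to compound 2 (0.34 log units; beyond the scatter) and resting on that single earlier pair, with the change of surroundings kept in mind. Compound 4 is accordingly estimated at 650 nM in this assay, with an expected range from 300 nM to 1500 nM.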

Compound 4, half-maximal inhibitory concentration: 1100 nM
For compound 4 the middle estimate is 1.7-fold (0.23 log units) below the measured one; the measured number falls inside the stated range.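

Working notes on the halogen swap: in this assay, bromo in place of chloro on the aromatic carbon para to a ((5-chloropyrazin-2-yl)carbonyl)oxy group gives no change at the digits printed from compound 3 to compound 4 (within the scatter). Set beside the earlier pair, the two steps cannot be told apart, so this series offers no sign that the core alters the outcome of the swap: the same change on two cores in this assay, a 2.2-fold lower number (0.34 log units; beyond the scatter) from compound 1 to compound 2 and no change at the digits printed (within the scatter) from compound 3 to compound 4, 2.2-fold (0.34 log units) apart, within the scatter of two such steps. This does not show that the swap carries over as a fixed step, since it rests on two pairs only, one step lies beyond the scatter and the other within it, and no general rule for the series can be drawn, nor any reason for either result.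

From the compounds shown here alone, only chloro and bromo appear at this place, so the effect of a fluoro, an iodo, a methyl or a methoxy group there remains open on both cores. The two cores also differ in more than one place, so the compounds shown do not separate any contribution of the ((5-chloropyrazin-2-yl)carbonyl)oxy group from that of the trifluoromethyl group, and a pair differing in only one of these would be needed to do so.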